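A few compounds are considered here, and "the series" means these few. Any claim that something is new, unique, unknown or untested is made for them only; others in the source may bear on it.

Measured in a functional assay on SK-N-SH cells (Homo sapiens) for cytotoxicity, read by MTT assay, with a stated time of 24 h; on this read-out lower numbers stand for stronger inhibition and higher numbers for weaker inhibition:
- Compound 1 `Cc1ccc(Cc2cn3cc(Cl)ccc3nc2=O)cc1`: 860 nM
- Compound 2 `O=c1nc2ccc(Cl)cn2cc1Cc1ccc(F)cc1`: 9860 nM
- Compound 3 `O=c1nc2ccc(Br)cn2cc1Cc1ccccc1`: 137000 nM

Compound 2, at 9860 nM, is the second highest of these three numbers, with compound 1 lower and compound 3 higher. Compound 4 `O=c1nc2ccc(Cl)cn2cc1Cc1ccc([N+](=O)[O-])cc1` keeps the rest of compound 2 and changes one group: nitro in place of fluoro on an aromatic carbon. In words, nitro takes the place of fluoro on an aromatic carbon, para to a large group.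

For the measured compounds named here, one measured step bears on this swap, at the same carbon: an 11-fold higher number from compound 1 to compound 2 (1.06 log units; beyond the scatter). It shows that changing this group can move the number well beyond the scatter. Going by the values given here, no compound with a nitro group has been measured, however, so the size and direction of the next step remain uncertain. Among the compounds with values here, a moderate step in this assay towards a lower number is a cautious expectation, since the only other group measured at this carbon, in compound 1, gives 860 nM. That expectation means an estimated 2.5-fold lower number from compound 2 to compound 4 (0.39 log units; beyond the scatter). The estimated value for compound 4 is 4000 nM, with an expected range from 500 nM to 30000 nM.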

Compound 4, half-maximal inhibitory concentration: 940 nM
The estimate for compound 4 lay 4.3-fold (0.63 log units) above the measured number, within the range that was stated.
By their numbers in this assay, from the lowest: compounds 1 and 4 (each within the scatter of the next); then compound 2; then compound 3.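

In this assay, the change from fluoro to nitro at this carbon gives a 10-fold lower number from compound 2 to compound 4 (1.02 log units; beyond the scatter). This shows that the earlier rise seen with fluoro can be undone by another group at the same place, so the number does not simply stay high once methyl is replaced. For the compounds shown here, the nitro and methyl compounds cannot be told apart, with a 1.1-fold higher number from compound 1 to compound 4 (0.04 log units; within the scatter), which leaves fluoro as the one group of these three that stands apart, and nothing measured here explains that difference.

Going by these compounds, it remains open whether an amine, a carboxylic acid or a methoxy group at this carbon would group with methyl and nitro or with fluoro. On these data alone, it is also open whether nitro would act the same way with bromo in place of chloro on the shared core.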